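The source may hold more compounds than are shown below. What is called first, only, known or untested is meant among the compounds shown, and "the series" means these compounds.

Compound 1 `Nc1cc(N)c2nc(-c3ccccc3)c(Oc3ccc(Cl)c(Cl)c3)nc2c1` is the point of departure. In a functional assay on HOP-62 cells (Homo sapiens) for inhibition, read by sulforhodamine B assay, with a stated time of 48 h (on this read-out higher numbers stand for weaker inhibition of growth and lower numbers for stronger inhibition of growth), compound 1 gives 17000 nM. Compound 3 `COc1cc(CNc2nc3cc(N)cc(N)c3nc2-c2ccccc2)cc(OC)c1OC` reads the same at the digits shown, giving 17000 nM in this assay, and compound 2 `Nc1cc(N)c2nc(-c3ccccc3)c(NCc3ccc(Cl)c(Cl)c3)nc2c1` gives 15800 nM in this assay, a number that lies within the usual scatter of the other two. On these three numbers compound 1 therefore stands nowhere apart: the three compounds, though they differ in the group attached beside the phenyl-bearing core, read alike within the scatter.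

The step to compound 4 `Nc1cc(N)c2nc(-c3ccccc3)c(Sc3ccc(Cl)c(Cl)c3)nc2c1` alters compound 1 in one place ((3,4-dichlorophenyl)sulfanyl in place of 3,4-dichlorophenoxy on an aromatic carbon). For the measured compounds named here, no measured pair in this set shows such an exchange directly. Since the three measured compounds, each with a different link to its outer ring, sit within the scatter of one another, the step from compound 1 to compound 4 is expected to be small, a 1.1-fold lower number from compound 1 to compound 4 (0.05 log units; within the scatter), with no direction beyond the scatter. Compound 4 is accordingly estimated at 15000 nM in this assay, within a range from 5000 nM to 45000 nM.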

Compound 4, concentration for 50% growth inhibition: 12300 nM
Compound 4: the middle estimate sits 1.2-fold (0.09 log units) above what was measured, within the range that was stated.
By their numbers in this assay, from the lowest: compounds 4, 2, 1 and 3 (each within the scatter of the next).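

In this assay, for the compounds shown here, the exchange of 3,4-dichlorophenoxy for (3,4-dichlorophenyl)sulfanyl gives the first step at this aromatic carbon that can be read directly, a 1.4-fold lower number from compound 1 to compound 4 (0.14 log units; within the scatter), and this step lies within the scatter. Going by these compounds alone, compounds 1, 2 and 3 differ from one another in more than one place, so only this pair isolates a single change, and it shows that replacing the linking oxygen with sulfur does not move the growth-inhibition number beyond the scatter. Nothing at hand gives a measured reason for the size of this step.

Going by these compounds, it remains open whether a smaller group at this carbon, such as a plain amine or a carboxylic acid, would move the number beyond the scatter. On these data alone, the effect of replacing the phenyl group on the shared core, for instance with a pyridine ring, also remains open.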